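The source may report more compounds than this note shows. Statements on the series, on what has been measured and on what is new or still open speak of the compounds shown alone.

Compound 1 `CCOC(=O)c1ccc(-c2nn(Cc3ccccc3OC)c3ccccc23)cc1`: > 10000 nM
Compound 2 `CCOC(=O)c1ccc(-c2nn(CC)c3ccccc23)cc1`: > 10000 nM

Both compounds were tested in a functional assay on cells (Platelet, Homo sapiens) for inhibition; on this read-out higher numbers stand for weaker inhibition and lower numbers for stronger inhibition. Compound 2 stands at > 10000 nM, which is a limit and not a number. Compound 1 gives > 10000 nM, which is also a limit. The record so far therefore holds only (the limit of > 10000 nM in this assay, at which 2 of the 2 values shown sit).

Compound 3 `CCCn1nc(-c2ccc(C(=O)OCC)cc2)c2ccccc21` differs from compound 2 by one change: methyl in place of hydrogen on a saturated chain carbon, two bonds along the chain from an aromatic nitrogen. This turns ethyl to propyl. Among the measured compounds shown here, the only measured step, a step that the two limits leave unreadable from compound 1 to compound 2, gives neither a size nor a direction to build on, so no step beyond the scatter is expected in this assay. The expected change is a step that the limit leaves unreadable from compound 2 to compound 3. For compound 3 the estimate is 15000 nM, with an expected range from 4000 nM to 50000 nM.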

Compound 3, half-maximal inhibitory concentration: > 10000 nM
Compound 3: only a limit was reported (the forecaster's own chance of this, stated with the estimate: 85%); the middle value lies beyond the limit too.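

Among the compounds shown here, compound 3 also gives only a limit, so no step among compound 1, compound 2 and compound 3 can be read. Going by these compounds, how strongly any of them acts in this assay, and whether the group on the aromatic nitrogen matters, stays open.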